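The compounds below may be only part of what the source reports. "The series", "measured", "known", "first", "only" and "open" are said of these compounds alone.

The measured compounds:
compound 1 `CCOC(=O)C12C(=O)OCC=C1COC2c1ccc(Cl)cc1` gives 118000 nM in a functional assay on HeLa cells (Homo sapiens) for cytotoxicity, read by MTT assay; a higher number here means a weaker inhibitor, a lower number a stronger inhibitor;
compound 2 `CCOC(=O)C12C(=O)OCC=C1COC2c1ccc(Cl)c(Cl)c1` gives 72400 nM;
compound 3 `CCOC(=O)C12C(=O)OCC=C1COC2c1cc(OC)cc(OC)c1` gives 16000 nM.

Among these three numbers compound 1 has the highest. Compound 2 is nearest, and the step of a 1.6-fold lower number from compound 1 to compound 2 (0.21 log units; within the scatter) is within the scatter; compound 3 sits furthest, its number lower beyond the scatter. Compound 4 `CCOC(=O)C12C(=O)OCC=C1COC2c1ccc([N+](=O)[O-])cc1` differs from compound 1 by nitro in place of chloro on an aromatic carbon. Among the compounds with values here, no measured step makes this exchange. Within the data shown here, the one single-place step, which puts chloro in place of hydrogen on an aromatic carbon, stays within the scatter, and the lower number of compound 3 comes with a different substitution that cannot be carried over. Compound 4 is therefore expected to move no further than the scatter, an expected step of a 1.3-fold lower number from compound 1 to compound 4 (0.12 log units; within the scatter). The estimate for compound 4 in this assay is 90000 nM, within 30000 nM to 300000 nM.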

Compound 4, half-maximal inhibitory concentration: 53400 nM
Beside the measured number, compound 4's estimate is 1.7-fold (0.23 log units) above it, and the stated range covers the measured number.
By their numbers in this assay, from the lowest: compound 3; then compounds 4, 2 and 1 (each within the scatter of the next, the first and the last beyond it).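

Nitro in place of chloro on this aromatic carbon, para to a large group, gives a 2.2-fold lower number from compound 1 to compound 4 (0.34 log units; beyond the scatter), the only single-place step shown that goes beyond the scatter. The number at this position therefore responds to the exchange, though modestly, whereas the step of a 1.6-fold lower number from compound 1 to compound 2 (0.21 log units; within the scatter), which adds a chloro elsewhere on the ring, does not leave the scatter. Nothing available bears on the reason for this change.

As far as these compounds go, whether an amine or a carboxylic acid on this carbon would move the number in this assay further, and in which direction, stays open. From the compounds shown here alone, how hydrogen on this carbon compares with chloro or nitro also stays open.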